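This account rests on a few compounds, and the source may have more. Where it says the series, first, only, none or still open, it means among the compounds named here.

Working notes on the series. Compound 1 `CCN(CC)c1cc2[nH]c(C3CCCCC3)nc2cc1NC(=O)c1ccc(F)cc1` reaches in an ADME assay on Vero cells (Chlorocebus sabaeus) for cytotoxicity, read by resazurin assay, with a stated time of 3 days (on this read-out lower numbers stand for stronger inhibition and higher numbers for weaker inhibition), only a limit, > 100 ug/mL. Compound 2 `CCCC(C)OC(=O)Nc1cc2nc(C3CCCCC3)[nH]c2cc1N(CC)CC` likewise gives in this assay only a limit, > 100 ug/mL. Compound 3 `CCN(CC)c1cc2[nH]c(C3CCCCC3)nc2cc1NC(=O)c1ccc(C)cc1` also stops in this assay at a limit, > 100 ug/mL. Compound 3 thus stands together with the other two at the limit of > 100 ug/mL in this assay, at which 3 of the 3 values shown sit, and the steps a step that the two limits leave unreadable from compound 1 to compound 2, a step that the two limits leave unreadable from compound 1 to compound 3 and a step that the two limits leave unreadable from compound 2 to compound 3 cannot be sized from these readings. Compound 4 `CCN(CC)c1cc2[nH]c(C3CCCCC3)nc2cc1NC(=O)c1ccc(F)cc1F` carries 2,4-difluorophenyl in place of 4-methylphenyl on a carbonyl carbon. Going by the values given here, no measured step bears readably on this change, so no direction is known; the step that the limit leaves unreadable from compound 3 to compound 4 is expected to stay within the scatter, with compound 4 again most likely reported only as a limit. The estimate for compound 4 in this assay is 150 ug/mL, within 70 ug/mL to 400 ug/mL.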

Compound 4, half-maximal inhibitory concentration: > 100 ug/mL
Compound 4: only a limit was reported (the forecaster's own chance of this, stated with the estimate: 85%); the middle value lies beyond the limit too.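

In this assay compound 4 again stops at a limit, as do compounds 1, 2 and 3, so none of its steps to them can be read: the limit of > 100 ug/mL in this assay, at which 4 of the 4 values shown sit.

The compounds shown leave open how far each lies from that limit, and whether any of these changes alters the read-out at all.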